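Free ring amine in place of tert-butoxycarbonyl carbamate

This account rests on a few compounds, and the source may have more. Where it says the series, first, only, none or still open, it means among the compounds named here.

Of the compounds shown here, two carry numbers so far. In a functional assay on K562 cells (Homo sapiens) for antiproliferative activity, read by CellTiter-Glo and CCK-8 assay, with a stated time of 72 h (a lower number here means a stronger inhibitor of growth, a higher number a weaker inhibitor of growth), compound 1 `Cc1ccc(NC(=O)c2cccc(C(F)(F)F)c2)cc1N1Cc2cnc(OC3CCN(C(=O)OC(C)(C)C)CC3)nc2N(C)C1=O` gives 29 nM. Compound 2 `Cc1cc(C)cc(C(=O)Nc2ccc(C)c(N3Cc4cnc(Nc5ccc(C)c(N)c5)nc4N(C)C3=O)c2)c1` gives 26 nM in this assay. Of the two numbers that of compound 1 is the higher one, yet the gap to compound 2 lies within the scatter, so the two compounds cannot be told apart on this assay. For the measured compounds named here, no step between measured compounds is recorded. Compound 3 `Cc1ccc(NC(=O)c2cccc(C(F)(F)F)c2)cc1N1Cc2cnc(OC3CCNCC3)nc2N(C)C1=O` is derived from compound 1 by one change: hydrogen in place of tert-butoxycarbonyl on an amine nitrogen in a ring. Going by the values given here, no measured pair shows this change, so its size is unknown from the data at hand. The step of a 1.6-fold lower number from compound 1 to compound 3 (0.21 log units; within the scatter) is expected to be small, staying close to the scatter or leaning toward a lower number. For compound 3 in this assay the estimate is 18 nM, with a range from 5 nM to 65 nM.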

Compound 3, concentration for 50% growth inhibition: 220 nM
For compound 3 the middle estimate is 12-fold (1.09 log units) below the measured one; the measured number lies above the stated range.
By their numbers in this assay, from the lowest: compounds 2 and 1 (each within the scatter of the next); then compound 3.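

For the compounds shown here, the amine nitrogen in the six-membered non-aromatic ring is the first place with a readable step. In this assay hydrogen in place of tert-butoxycarbonyl gives a 7.6-fold higher number from compound 1 to compound 3 (0.88 log units; beyond the scatter) and shows that this nitrogen is not indifferent to what it carries. In this single pair, the lower number goes with the tert-butoxycarbonyl group, so the free ring amine offers no gain here, and no measurement at hand bears on why the number rises.

Open, from the compounds shown here alone, is whether an acetyl or a methyl group on this nitrogen would stay close to compound 1 or to compound 3, which would show how much of the tert-butoxycarbonyl group the number depends on. Also open, going by these compounds, is whether the same change would give a step of similar size on another member of the series.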